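A few compounds are considered here, and "the series" means these few. Any claim that something is new, unique, unknown or untested is made for them only; others in the source may bear on it.

Compound 1 `CC(C)(C)n1cc2c(n1)C(=O)CC1(CCN(C(=O)c3cc(-c4ccccc4Cl)nc4ccccc34)CC1)O2` is the starting point. In a functional assay on HepG2 cells (Homo sapiens) for inhibition, read by MTT assay, with a stated time of 72 h (on this read-out higher numbers stand for weaker inhibition and lower numbers for stronger inhibition), compound 1 gives > 10000 nM, a limit of the assay rather than a number. Compound 2 `COc1ccc(-c2cc(C(=O)N3CCC4(CC3)CC(=O)c3nn(C(C)(C)C)cc3O4)c3ccccc3n2)cc1OC` gives 1560 nM in this assay. Compound 3 `CCOc1cc(C(=O)N2CCC3(CC2)CC(=O)c2nn(C(C)(C)C)cc2O3)c2ccccc2n1` gives > 10000 nM in this assay, again a limit of the assay. Among the measured steps, an at least 6.4-fold lower number from compound 1 to compound 2 (0.80 log units; beyond the scatter) and an at least 6.4-fold higher number from compound 2 to compound 3 (0.80 log units; beyond the scatter). Compound 4 `CC(C)Oc1cc(C(=O)N2CCC3(CC2)CC(=O)c2nn(C(C)(C)C)cc2O3)c2ccccc2n1` carries isopropoxy in place of 2-chlorophenyl on an aromatic carbon. The step that bears most directly on it is a step that the two limits leave unreadable from compound 1 to compound 3, where ethoxy replaced 2-chlorophenyl and the limit of > 10000 nM in this assay, at which 2 of the 3 values shown sit, leaves its size unreadable. Compound 4 is therefore expected to remain at the limit, with an estimate of 20000 nM in a range of 8000 nM to 60000 nM. The expected step is thus a step that the limit leaves unreadable from compound 1 to compound 4.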

Compound 4, half-maximal inhibitory concentration: 3150 nM
Compound 4: the middle estimate sits 6.3-fold (0.80 log units) above what was measured, outside the stated range (below it).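

Next to the ring nitrogen, one added methyl turns ethoxy into isopropoxy and brings a readable value: an at least 3.1-fold lower number from compound 3 to compound 4 (0.50 log units; beyond the scatter). A ring is therefore not required at this place, as an at least 3.1-fold lower number from compound 1 to compound 4 (0.50 log units; beyond the scatter) shows, although 3,4-dimethoxyphenyl keeps an edge, with a 2.0-fold higher number from compound 2 to compound 4 (0.31 log units; beyond the scatter). Compound 1 and compound 3 each stand at a limit of the assay, so the first two steps give only a minimum size: the limit of > 10000 nM in this assay, at which 2 of the 4 values shown sit.

On these data alone, whether a longer chain such as butoxy would lower the number further stays open. So does the effect of an amine at this place.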